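Swapping the amide aryl group in a flavonol series

This account rests on a few compounds, and the source may have more. Where it says the series, first, only, none or still open, it means among the compounds named here.

Two compounds from a set built on one shared core have been measured in a functional assay on MDA-MB-231 cells (Homo sapiens) for antiproliferative activity, read by CCK-8 assay, with a stated time of 72 h; a higher number here means a weaker inhibitor, a lower number a stronger inhibitor. Compound 1 `COc1ccccc1C(=O)Nc1cccc(-c2oc3cc(-c4ccc(F)cc4)ccc3c(=O)c2O)c1` gives 5110 nM. Compound 2 `COc1ccc(C(=O)Nc2cccc(-c3oc4cc(-c5ccc(F)cc5)ccc4c(=O)c3O)c2)c(F)c1` gives 17600 nM, which is the higher of the two numbers, so compound 2 is the weaker inhibitor of the pair. For the measured compounds named here, the one step that links them, a 3.4-fold higher number from compound 1 to compound 2 (0.54 log units; beyond the scatter), shows that exchanging the aryl group on the amide carbonyl can move the number modestly.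

Compound 3 `O=C(Nc1cccc(-c2oc3cc(-c4ccc(F)cc4)ccc3c(=O)c2O)c1)c1ccc(Cl)nc1` is not yet measured. It differs from compound 2 in that same place: 6-chloropyridin-3-yl in place of 2-fluoro-4-methoxyphenyl on a carbonyl carbon. Going by the values given here, the only step that bears on this change is the one from compound 1 to compound 2, and it concerned a different pair of aryl groups, so it gives the size of shift such a swap can produce but not its direction. Because compound 1 gives 5110 nM with another aryl group in this place, the number for compound 3 is expected to lie between the two measured values or near them, and the step of a 2.0-fold lower number from compound 2 to compound 3 (0.29 log units; within the scatter) is estimated to be modest. Compound 3 is estimated to give 9000 nM in this assay, within a range from 2500 nM to 35000 nM.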

Compound 3, half-maximal inhibitory concentration: 1760 nM
The estimate for compound 3 lay 5.1-fold (0.71 log units) above the measured number; the measured number lies below the stated range.
By their numbers in this assay, from the lowest: compound 3; then compound 1; then compound 2.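

In this assay, placing 6-chloropyridin-3-yl on the carbonyl carbon gives a 10-fold lower number from compound 2 to compound 3 (1.00 log units; beyond the scatter) and also a 2.9-fold lower number from compound 1 to compound 3 (0.46 log units; beyond the scatter). The earlier step, a 3.4-fold higher number from compound 1 to compound 2 (0.54 log units; beyond the scatter), moved the number upward only, so this position can now be seen to shift the number in either direction, and compound 3 has the lowest number of the three, with its steps to both other compounds beyond the scatter. The change is also the first here to put a six-membered aromatic ring with a hetero atom at this position, although the chlorine enters and the fluorine and methoxy leave in the same step.

Nothing in the available data explains why the number falls with this group. The compounds shown do not separate the part played by the ring nitrogen from that of the chlorine, and they leave open what a pyridin-3-yl without chlorine, a 4-chlorophenyl or a 6-aminopyridin-3-yl would give at this position.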